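From ethylcarbamoyl to allylcarbamoyl in an adenosine series

The compounds below may be only part of what the source reports. "The series", "measured", "known", "first", "only" and "open" are said of these compounds alone.

Compound 1 `CCNC(=O)OC[C@H]1OC(n2cnc3c(NC4CCOC4)ncnc32)[C@H](O)[C@@H]1O` was tested in an assay on DDT1 cells (Cricetulus griseus) for binding affinity to adenosine receptor A1 (Homo sapiens), read by radioligand binding (on this read-out higher numbers stand for weaker inhibition and lower numbers for stronger inhibition), where compound 1 gives 167 nM. Within the three measured compounds this places compound 1 second highest: compound 2 `CCCNC(=O)OC[C@H]1OC(n2cnc3c(NC4CCOC4)ncnc32)[C@H](O)[C@@H]1O` gives 235 nM, and compound 3 `C=CC/N=C(\S)OC[C@H]1OC(n2cnc3c(NC4CCOC4)ncnc32)[C@H](O)[C@@H]1O` gives 35 nM. The step of a 1.4-fold higher number from compound 1 to compound 2 (0.15 log units; within the scatter) lies within the scatter, while a 4.8-fold lower number from compound 1 to compound 3 (0.68 log units; beyond the scatter) and a 6.7-fold lower number from compound 2 to compound 3 (0.83 log units; beyond the scatter) are modest steps beyond it.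

The unmeasured compound 4 `C=CCNC(=O)OC[C@H]1OC(n2cnc3c(NC4CCOC4)ncnc32)[C@H](O)[C@@H]1O` differs from compound 1 in one place: vinyl in place of methyl on a saturated chain carbon bound to an amide-type nitrogen. Going by the values given here, the only measured step that changes this chain alone, a 1.4-fold higher number from compound 1 to compound 2 (0.15 log units; within the scatter), stayed within the scatter. Compound 3 carries the allyl chain too, but its step from compound 1 also exchanges the group on the oxygen, so it cannot be read as a chain effect by itself.

Compound 4 is therefore expected to sit close to compound 1, with an estimated step of a 1.2-fold lower number from compound 1 to compound 4 (0.08 log units; within the scatter) that does not clearly exceed the scatter. The estimate for compound 4 in this assay is 140 nM, with a range from 55 nM to 360 nM.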

Compound 4, inhibition constant: 524 nM
Estimate against measurement, compound 4: 3.7-fold (0.57 log units) below; the measured number lies above the stated range.
By their numbers in this assay, from the lowest: compound 3; then compounds 1 and 2 (each within the scatter of the next); then compound 4.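

At this position, the double bond changes the result in a way the saturated chains did not: in this assay, a 1.4-fold higher number from compound 1 to compound 2 (0.15 log units; within the scatter) stayed within the scatter, but a 3.1-fold higher number from compound 1 to compound 4 (0.50 log units; beyond the scatter) and a 2.2-fold higher number from compound 2 to compound 4 (0.35 log units; beyond the scatter) both go beyond it. With the allyl chain present in both compounds, the exchange of the group on the oxygen gives a 15-fold higher number from compound 3 to compound 4 (1.18 log units; beyond the scatter), so the allyl chain does not by itself carry the low number of compound 3. Nothing available here explains either step.

Going by these compounds, it remains open whether a propargyl chain, with a triple bond, or a cyclopropylmethyl chain would follow the allyl chain or the saturated ones. On these data alone, it is also open whether the sulfur-bearing group of compound 3 would give a step of similar size on an ethyl or propyl chain.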